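Carrying a Methoxy Addition From One Core to Another

The compounds below may be only part of what the source reports. "The series", "measured", "known", "first", "only" and "open" are said of these compounds alone.

Measured compounds:
compound 1, `Cc1ccc(C(=O)c2ccc(OCC(=O)Nc3nc(-c4ccccc4)cs3)c(C)c2)cc1`: 27100 nM
compound 2, `COc1ccc(-c2csc(NC(=O)COc3ccc(C(=O)c4ccc(C)cc4)cc3C)n2)cc1`: 18700 nM
compound 3, `Cc1cc(C(=O)c2ccccc2)cc(C)c1OCC(=O)Nc1nc(-c2ccccc2)cs1`: 19900 nM

All three were tested in a functional assay on DLA cells (Mus musculus) for cytotoxicity, read by LDH release, with a stated time of 48 h; a higher number here means a weaker inhibitor, a lower number a stronger inhibitor. Compound 2 differs from compound 1 by methoxy in place of hydrogen on an aromatic carbon; the result was a 1.4-fold lower number from compound 1 to compound 2 (0.16 log units; within the scatter). Compound 3 is built from the same atoms as compound 1 joined differently, and the difference between the two cores is not broken down here. Compound 4, `COc1ccc(-c2csc(NC(=O)COc3c(C)cc(C(=O)c4ccccc4)cc3C)n2)cc1`, has not yet been measured; it differs from compound 3 by methoxy in place of hydrogen on an aromatic carbon, the same change as from compound 1 to compound 2, made at a place described in the same words. Because a 1.4-fold lower number from compound 1 to compound 2 (0.16 log units; within the scatter) lay within the scatter, the expected step of a 1.3-fold lower number from compound 3 to compound 4 (0.12 log units; within the scatter) is likewise small. Compound 4 is therefore estimated at 15000 nM in this assay, with an expected range from 7000 nM to 32000 nM.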

Compound 4, half-maximal inhibitory concentration: 40100 nM
Compound 4: middle estimate off by 2.7-fold (0.43 log units), on the low side, outside the stated range (above it).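

In this assay the change from phenyl to 4-methoxyphenyl gave a 2.0-fold higher number from compound 3 to compound 4 (0.30 log units; within the scatter) on the core of compound 3, and this did not repeat the earlier step on the core of compound 1: the same change on two cores in this assay, a 1.4-fold lower number (0.16 log units; within the scatter) from compound 1 to compound 2 and a 2.0-fold higher number (0.30 log units; within the scatter) from compound 3 to compound 4, 2.9-fold (0.47 log units) apart, beyond the scatter of two such steps. Each step taken alone lies within the scatter, and the finding rests on the gap between them: the size of this change cannot be assumed to carry from one of these two cores to the other. Two pairs do not show which feature of the cores sets the steps apart, nor how the change would behave on any further core.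

Still open, going by these compounds, is whether a hydroxyl group, a fluorine atom or a dimethylamino group in the same place would also give different steps on the two cores.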